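The compounds below may be only part of what the source reports. "The series", "measured", "known", "first", "only" and "open" are said of these compounds alone.

Measured so far in an ADME assay on SH-SY5Y cells (Homo sapiens) for cytotoxicity, read by MTT assay, with a stated time of 24 h, tested at 12.5 uM; a lower number here means a stronger effect, a higher number a weaker effect of the compound at the concentration tested:
Compound 1, `COc1cc2c(cc1O)CCC(C)(CC(=O)O)O2`, gives 92%.
Compound 2, `COc1cc2c(cc1O)CCC(C)(CC(N)=O)O2`, gives 100%.
Compound 3, `COc1cc2c(cc1O)CCC(C)(CC(=O)N[C@@H](CCC(N)=O)C(=O)O)O2`, gives 84.8%.

Compound 2 stands highest of these three numbers. Its nearest neighbour is compound 1, with a step of a number 8 percentage points higher from compound 1 to compound 2 (within the scatter). Its furthest is compound 3, with a step of a number 15.2 percentage points lower from compound 2 to compound 3 (beyond the scatter).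

The next compound, compound 4, `COc1cc2c(cc1O)CCC(C)(CCNC(C)=O)O2`, is made from compound 2 by one change: acetamidomethyl in place of carbamoyl on a saturated chain carbon bound to a saturated ring carbon. Both measured steps sit on the same side chain as this change. The swap at the carbonyl carbon, a number 8 percentage points higher from compound 1 to compound 2 (within the scatter), stayed within the scatter, while adding a larger group on the amide-type nitrogen, a number 15.2 percentage points lower from compound 2 to compound 3 (beyond the scatter), lowered the number modestly. The change to compound 4 also lengthens this arm, but keeps a single hydrogen-bond donor and acceptor, so only a small step downward, or none beyond the scatter, is expected, an expected step of a number 7 percentage points lower from compound 2 to compound 4 (within the scatter). Compound 4 is therefore estimated at 93%, with a range from 80% to 100%.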

Compound 4, a percentage reported as activity, at one concentration (the size of the read-out at that concentration, not a potency): 83.5%
Estimate against measurement, compound 4: 9.5 percentage points above; the measured number falls inside the stated range.
By their numbers in this assay, from the lowest: compounds 4, 3, 1 and 2 (each within the scatter of the next, the first and the last beyond it).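

In this assay, acetamidomethyl in place of carbamoyl gives a number 16.5 percentage points lower from compound 2 to compound 4 (beyond the scatter), even though the entering and leaving groups have the same hydrogen-bond donor and acceptor counts and neither carries a net charge. Acetamidomethyl in place of carboxy at the same place gives a number 8.5 percentage points lower from compound 1 to compound 4 (within the scatter), so this change separates compound 4 from compound 2 but not from compound 1. No measurement shown here accounts for the step from the carbamoyl group.

The entering group is both larger than carbamoyl and differently built, so the compounds shown cannot tell whether the added atoms or the altered amide matters more. An amine at the end of this chain, or a plain alkyl chain with no amide, would help to pull these two apart.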